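The source may hold more compounds than are shown below. What is called first, only, known or untested is meant among the compounds shown, and "the series" means these compounds.

Measured compounds:
- compound 1, `CN(c1ccc2cc(NC(=O)CCc3ccc(C(F)(F)F)cc3)ccc2n1)C1CCCCC1`: 1200 nM
- compound 2, `CN(C)c1ccc2cc(NC(=O)CCc3ccc(C(F)(F)F)cc3)ccc2n1`: 110 nM
- compound 3, `O=C(CCc1ccc(C(F)(F)F)cc1)Nc1ccc2nc(N3CCCCCC3)ccc2c1`: 1800 nM

In a functional assay on HEK293 cells for activation of melanin-concentrating hormone receptor 1 (Rattus norvegicus), read by inositol phosphate accumulation (on this read-out higher numbers stand for an effect only at larger amounts of compound and lower numbers for an effect already at smaller amounts), compound 1 stands second highest of the three numbers. Its nearest neighbour is compound 3, reached by a 1.5-fold higher number from compound 1 to compound 3 (0.18 log units; within the scatter), a step within the scatter. The furthest is compound 2, reached by an 11-fold lower number from compound 1 to compound 2 (1.04 log units; beyond the scatter), a large step beyond the scatter.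

The step under study leads from compound 1 to compound 4, `CC(=O)NC1CCN(c2ccc3cc(NC(=O)CCc4ccc(C(F)(F)F)cc4)ccc3n2)C1`, which has not yet been measured in this assay. The change is 3-acetamidopyrrolidin-1-yl in place of cyclohexyl(methyl)amino on an aromatic carbon. Among the measured compounds shown here, two measured steps bear on it, both altering the group on the same aromatic carbon of the shared core. Replacing cyclohexyl(methyl)amino with azepan-1-yl left the number essentially unchanged, as a 1.5-fold higher number from compound 1 to compound 3 (0.18 log units; within the scatter) shows. Replacing the cyclohexyl with methyl on that nitrogen gave an 11-fold lower number from compound 1 to compound 2 (1.04 log units; beyond the scatter), a large drop in the number. For the measured compounds named here, the entering 3-acetamidopyrrolidin-1-yl is a ring amine, like azepan-1-yl in compound 3, but it carries an acetamido group with one hydrogen-bond donor that no measured compound has, so the direction is uncertain. Compound 4 is therefore expected to give 500 nM in this assay, within a wide range from 120 nM to 2500 nM. This estimate corresponds to a 2.4-fold lower number from compound 1 to compound 4 (0.38 log units; beyond the scatter), a modest expected improvement that may fall within the scatter.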

Compound 4, half-maximal effective concentration: 440 nM
Compound 4: the middle estimate sits 1.1-fold (0.06 log units) above what was measured; low and high end bracket the measured number.
By their numbers in this assay, from the lowest: compound 2; then compound 4; then compounds 1 and 3 (each within the scatter of the next).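

In this assay, among the compounds shown here, the aromatic carbon next to the ring nitrogen takes 3-acetamidopyrrolidin-1-yl, the first group here with a hydrogen-bond donor, and the number falls modestly: a 2.7-fold lower number from compound 1 to compound 4 (0.44 log units; beyond the scatter) and a 4.1-fold lower number from compound 3 to compound 4 (0.61 log units; beyond the scatter). Heavy-atom count alone does not follow the number in the step from cyclohexyl(methyl)amino, since the entering group has more heavy atoms yet gives the lower number, which the earlier compounds could not show. The small dimethylamino nevertheless remains ahead, with a 4.0-fold higher number from compound 2 to compound 4 (0.60 log units; beyond the scatter), so compound 2 keeps the lowest number of the four.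

Nothing available explains why these numbers differ. From the compounds shown here alone, it remains open whether the step to compound 4 comes from the acetamido group or from the five-membered ring, a question that an unsubstituted pyrrolidin-1-yl on the same aromatic carbon would address, while a 3-aminopyrrolidin-1-yl would test whether the acetyl part of that group matters.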